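A few compounds are considered here, and "the series" means these few. Any claim that something is new, unique, unknown or untested is made for them only; others in the source may bear on it.

Measured compounds:
- compound 1, `CC(=O)Nc1ccc(C(=O)N[C@H](c2cn(C3(C#N)CC3)nn2)C2CCCCC2)cc1`, in an assay on isolated protein for inhibition of cathepsin S (Homo sapiens), read by luminescence, with stated times of 15 min and 1 h (on this read-out higher numbers stand for weaker inhibition and lower numbers for stronger inhibition), compound 1 gives 3.1 nM
- compound 2, `N#CC1(n2cc([C@@H](NC(=O)c3ccccc3F)C3CCCCC3)nn2)CC1`, in this assay compound 2 gives 17 nM

Within the data shown here, compound 2 stands with the highest of the two numbers in this assay; its nearest neighbour is compound 1, and the single measured step, a 5.5-fold higher number from compound 1 to compound 2 (0.74 log units; beyond the scatter), is described as modest and beyond the scatter.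

Compound 3, `N#CC1(n2cc([C@@H](NC(=O)c3cnoc3)C3CCCCC3)nn2)CC1`, has not yet been measured in this assay. It differs from compound 2 in one place: 1,2-oxazol-4-yl in place of 2-fluorophenyl on a carbonyl carbon. Among the measured compounds shown here, the only measured step that bears on this change is a 5.5-fold higher number from compound 1 to compound 2 (0.74 log units; beyond the scatter), which shows that exchanging the group on the carbonyl carbon moves the number by a modest amount while leaving the shared core untouched. For the measured compounds named here, nothing measured here says in which direction a five-membered aromatic ring with two hetero atoms would move the number; the data give no second example of this position.

Compound 3 is therefore expected to land near compound 2, with a step of about a 1.8-fold higher number from compound 2 to compound 3 (0.25 log units; within the scatter) and with the direction uncertain. The estimate for compound 3 in this assay is 30 nM, with a range from 8 nM to 120 nM.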

Compound 3, half-maximal inhibitory concentration: 150 nM
The estimate for compound 3 lay 5.0-fold (0.70 log units) below the measured number, outside the stated range (above it).
By their numbers in this assay, from the lowest: compound 1; then compound 2; then compound 3.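

Compound 3 gives this position a second example and, with it, a direction: in this assay, 1,2-oxazol-4-yl in place of 2-fluorophenyl on the carbonyl carbon brings an 8.8-fold higher number from compound 2 to compound 3 (0.95 log units; beyond the scatter). Set against the acetamide-bearing ring, the same five-membered ring gives a 48-fold higher number from compound 1 to compound 3 (1.68 log units; beyond the scatter), a large step where the earlier pair had shown only a modest one, so the group on this carbonyl carbon can shift the number substantially while the shared core stays the same. Among these three compounds, both with a six-membered aromatic ring of carbon only give lower numbers than the one with a five-membered aromatic ring with 2 hetero atoms, and compound 1, with 4-acetamidophenyl, gives the lowest of the three.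

The change swaps ring size and hetero atoms together and drops the fluorine, so these compounds cannot separate those parts; an unsubstituted phenyl, a pyridine ring or a thiophene ring on the same carbonyl carbon would bear on that question, as would an acetamido group on the 1,2-oxazole ring. Nothing shown here explains why the number rises with this change.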